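The source may report more compounds than this note shows. Statements on the series, on what has been measured and on what is new or still open speak of the compounds shown alone.

This study looks at cytotoxicity, measured in an ADME assay on Vero cells (Chlorocebus sabaeus) for cytotoxicity, with a stated time of 72 h; on this read-out higher numbers stand for weaker inhibition and lower numbers for stronger inhibition. Compound 1, `COc1ccc(-c2ccc(CO[C@@H]3COc4nc([N+](=O)[O-])cn4C3)s2)cn1`, is one of two compounds with a result so far. In this assay compound 1 gives only a limit rather than a number, > 128000 nM. Compound 2, `O=[N+]([O-])c1cn2c(n1)OC[C@@H](OCc1cnn(-c3ccc(C(F)(F)F)cc3)c1)C2`, is the starting point of the step followed here. In this assay compound 2 likewise gives only a limit, > 128000 nM. Both results sit at the same place, namely (the limit of > 128000 nM in this assay, at which 2 of the 2 values shown sit). On the numbers shown, nothing separates compound 2 from compound 1, and neither can be ranked against the other.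

Compound 3, `O=[N+]([O-])c1cn2c(n1)OC[C@@H](OCc1cnn(-c3ccc(OC(F)(F)F)cc3)c1)C2`, has not yet been measured. It differs from compound 2 in one place: trifluoromethoxy in place of trifluoromethyl on an aromatic carbon. Among the measured compounds shown here, no step between two measured compounds is available to show how such a change moves this read-out, so there is nothing to point to a shift in either direction. The expected step from compound 2 to compound 3 in this assay is a step that the limit leaves unreadable from compound 2 to compound 3, none beyond the usual scatter. Compound 3 is therefore estimated to come out at about 150000 nM, within a range from 60000 nM to 400000 nM, and most likely reported again only as a limit.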

Compound 3, half-maximal inhibitory concentration: > 128000 nM
Compound 3 gave a limit, no number; the forecaster's own chance of this, stated with the estimate: 85%; the middle value does not contradict the limit.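

Compound 2 and compound 3 each give only a limit in this assay and so no step can be read from compound 2 to compound 3: the limit of > 128000 nM in this assay, at which 3 of the 3 values shown sit. The compounds shown leave open where the true value of each one lies, and whether trifluoromethoxy and trifluoromethyl differ on this read-out at all.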